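The compounds below may be only part of what the source reports. "The series", "measured", "known", "first", "only" and "open" are said of these compounds alone.

Measured compounds:
- compound 1, `CC(=O)OC/C(=C\c1ccccc1)C(=O)c1ccccc1`: in a functional assay on SW1573 cells (Homo sapiens) for inhibition, read by sulforhodamine B assay, with a stated time of 48 h (a lower number here means a stronger inhibitor of growth, a higher number a weaker inhibitor of growth), compound 1 gives 4800 nM
- compound 2, `CC(=O)OC/C(=C\c1ccc(Cl)cc1)C(=O)c1ccccc1`: in this assay compound 2 gives 2600 nM
- compound 3, `CC(=O)OC/C(=C/c1ccccc1Cl)C(=O)c1ccccc1`: in this assay compound 3 gives 14000 nM

Compound 4, `CC(=O)OC/C(=C/c1ccc(Cl)cc1Cl)C(=O)c1ccccc1`, has not yet been measured in this assay.

Among the measured compounds shown here, the one measured pair that differs in a single place is compound 1 and compound 2. The change is chloro in place of hydrogen on an aromatic carbon. It made a 1.8-fold lower number from compound 1 to compound 2 (0.27 log units; within the scatter), so compound 1 and compound 2 are treated here as equivalent.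

Compound 3 carries its chloro group elsewhere on the ring; the difference between the core of compound 3 and the core of compound 1 is not broken down here. Compound 3 stands at the high end of the three values: its number is beyond the scatter above both compound 1 and compound 2.

Compound 4 derives from compound 3 by chloro in place of hydrogen on an aromatic carbon. This is the same kind of change as from compound 1 to compound 2, not the same: in compound 4 the entering chloro sits meta to a chloro group and para to a large group, whereas in compound 2 it sits only para to a large group.

For the measured compounds named here, with a single precedent of a small step, the expectation for compound 4 in this assay is a step of about the same size as the one from compound 1 to compound 2, starting from compound 3 at 14000 nM, because a 1.8-fold lower number from compound 1 to compound 2 (0.27 log units; within the scatter) was within the scatter. The step from compound 3 to compound 4 is therefore estimated as a 1.6-fold lower number from compound 3 to compound 4 (0.19 log units; within the scatter). Compound 4 is accordingly expected to give about 9000 nM, with a range from 4000 nM to 20000 nM.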

Compound 4, concentration for 50% growth inhibition: 22000 nM
The estimate for compound 4 lay 2.4-fold (0.39 log units) below the measured number; the measured number lies above the stated range.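

In this assay, the new step, a 1.6-fold higher number from compound 3 to compound 4 (0.20 log units; within the scatter), is small taken alone, and the two compounds count as equivalent. Set beside the earlier step, the result is that chloro in place of hydrogen on an aromatic carbon does not carry over from one core to the other as a fixed increment: the same change on two cores in this assay, a 1.8-fold lower number (0.27 log units; within the scatter) from compound 1 to compound 2 and a 1.6-fold higher number (0.20 log units; within the scatter) from compound 3 to compound 4, 2.9-fold (0.46 log units) apart, beyond the scatter of two such steps Neither step on its own lies beyond the scatter, so no firm reversal of direction can be claimed, and two pairs give neither a rule for further cores in this series nor an explanation of the gap between the steps.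

Open, on these data alone, is whether a fluoro group, a methoxy group or an amine at the place of the entering chloro would give steps that agree across the core of compound 1 and the core of compound 3, and whether the gap seen here depends on the chloro group already present in compound 3. Also open, as far as these compounds go, is how the same chloro change behaves when the acetate ester gives way to a free hydroxyl or a longer acyl chain.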